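The source may hold more compounds than are shown below. What is called first, only, known or untested is meant among the compounds shown, and "the series" means these compounds.

Measured so far:
- compound 1, `O=[N+]([O-])c1ccc([S+]([O-])C(F)F)cc1`: 1.37
- compound 2, `FC(F)SCCc1ccccc1`: 3.16

Of the compounds shown here, two have been measured in a physicochemical assay for lipophilicity, read by spectrophotometry, using the shake flask method, measured as octanol-water partition; on this read-out higher numbers stand for higher lipophilicity and lower numbers for lower lipophilicity. Compound 1, `O=[N+]([O-])c1ccc([S+]([O-])C(F)F)cc1`, gives 1.37 in this assay. Compound 2, `FC(F)SCCc1ccccc1`, gives 3.16 in this assay, and of the two numbers this is the higher one, standing well beyond the usual scatter above the value of compound 1. The two compounds share no common core, so their two values show only that one lies clearly above the other.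

The next compound to be measured is compound 3, `C[S+]([O-])CCc1ccccc1`. It differs from compound 2 in one place: a group of 3 heavy atoms (1 carbon, 1 oxygen, 1 sulfur; no ring) in place of a group of 4 heavy atoms (1 carbon, 2 fluorine, 1 sulfur; no ring), on a saturated chain carbon, two bonds along the chain from an aromatic carbon. Within the data shown here, no step between two measured compounds covers this change, so the direction and size can only be expected, not read off. On the numbers available, compound 3 is expected to come out clearly lower than compound 2 in this assay, by a step of about a number 1.96 log units lower from compound 2 to compound 3 (beyond the scatter), well beyond the scatter. The estimate for compound 3 in this assay is therefore 1.2, with a likely range from 0.6 to 1.8.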

Compound 3, partition coefficient: 0.63
Compound 3: middle estimate off by 0.57 log units, on the high side; measured number inside the range.
By their numbers in this assay, from the lowest: compound 3; then compound 1; then compound 2.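

Among these compounds, this is the first pair that differs in only one place, so this assay can now be read for a single change on a saturated chain carbon, two bonds along the chain from an aromatic carbon. Replacing the (difluoromethyl)sulfanyl group with the group of 3 heavy atoms gives a number 2.53 log units lower from compound 2 to compound 3 (beyond the scatter) and this counts as a large step for one small swap. The two groups have the same counts of 0 hydrogen-bond donors and 1 hydrogen-bond acceptor and neither carries a net charge, so these counts do not separate them, and no measurement on hand explains the size of the step.

On these data alone, the swap alters several atoms at once, so it remains open how much of the step goes with losing the two fluorine atoms and how much with gaining the oxygen, and a methylsulfanyl group, made of one sulfur and one methyl carbon, at the same place would help to separate the two. As far as these compounds go, whether the same swap gives a step of similar size on another core also remains open.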